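Adding a fluorine to a urea that stabilises a kinase

The source may hold more compounds than are shown below. What is called first, only, known or untested is meant among the compounds shown, and "the series" means these compounds.

Measured compounds:
- compound 1 `Cc1ccccc1NC(=O)Nc1cc(C(C)(C)C)nn1-c1ccccc1`: 8.6 degrees C
- compound 2 `Cc1cc(C)cc(NC(=O)Nc2cc(C(C)(C)C)nn2-c2ccccc2)c1`: -0.3 degrees C

In an assay on isolated protein for inhibition of serine/threonine-protein kinase 10 (Homo sapiens), read by thermal shift assay, tested at 10 uM (a higher number here means that the compound stabilises the target more against heat, a lower number that the compound stabilises the target less), compound 1 gives 8.6 degrees C and stands highest of the two numbers measured. Its nearest neighbour is compound 2, which gives -0.3 degrees C; the change from a 2-methylphenyl to a 3,5-dimethylphenyl on the amide-type nitrogen brings a number 8.9 degrees C lower from compound 1 to compound 2 (beyond the scatter), a large drop in this assay.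

Compound 3 `Cc1ccc(F)cc1NC(=O)Nc1cc(C(C)(C)C)nn1-c1ccccc1` differs from compound 1 in a smaller way: fluoro in place of hydrogen on an aromatic carbon. The fluorine enters on the same ring that was exchanged between compound 1 and compound 2, para to the methyl group, but the 2-methylphenyl arrangement of compound 1 is kept. For the measured compounds named here, no measured step tests a fluoro for hydrogen exchange, so the only guide is that compound 1 itself sits high. A modest step, if any, is expected: a number 1.1 degrees C lower from compound 1 to compound 3 (beyond the scatter). Compound 3 is therefore estimated at 7.5 degrees C, with a range from 4 degrees C to 10.5 degrees C.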

Compound 3, shift of the target's melting temperature: 4.1 degrees C
The estimate for compound 3 lay 3.4 degrees C above the measured number; measured number inside the range.
By their numbers in this assay, from the lowest: compound 2; then compound 3; then compound 1.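

In this assay, a single fluoro on an aromatic carbon, para to a methyl group, gives a number 4.5 degrees C lower from compound 1 to compound 3 (beyond the scatter) and shows that the read-out is sensitive to one added heavy atom at this place on the 2-methylphenyl ring. The 5-fluoro-2-methylphenyl group still keeps part of the stabilisation, as its exchange for the 3,5-dimethylphenyl group gives a number 4.4 degrees C higher from compound 2 to compound 3 (beyond the scatter) and leaves compound 3 in the middle of the three numbers. Nothing available here bears on what lies behind the drop caused by the fluoro group.

Three compounds cannot show whether the drop is specific to fluoro or would also follow from a chloro, a methoxy or an amine on the same carbon. On these data alone, it also remains open whether a fluoro on another carbon of this ring would lower the number as much.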